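This account rests on a few compounds, and the source may have more. Where it says the series, first, only, none or still open, it means among the compounds named here.

Compound 1 `N#CCCN(Cc1cccs1)S(=O)(=O)c1ccc(Cl)cc1`: > 195000 nM
Compound 2 `N#CCCN(Cc1cccs1)S(=O)(=O)c1ccc(N)cc1`: > 207000 nM

In an ADME assay on MDCK cells (Canis lupus familiaris) for cytotoxicity, read by MTT assay, with a stated time of 24 h (on this read-out higher numbers stand for lower toxicity in this test and lower numbers for higher toxicity in this test), compound 1 gives only a limit, > 195000 nM. Compound 2 also gives only a limit, > 207000 nM. Within the data shown here, the one measured step, a step that the two limits leave unreadable from compound 1 to compound 2, is amino in place of chloro on an aromatic carbon, and it does not touch the place that changes next. Compound 3 `N#CCCN(Cc1ccco1)S(=O)(=O)c1ccc(Cl)cc1` differs from compound 1 by furan-2-yl in place of thiophen-2-yl on a saturated chain carbon bound to a sulfonamide nitrogen. Among the measured compounds shown here, no measured step bears directly on this change. In this assay no shift beyond the scatter is expected in either direction, and the expected step is a step that the limit leaves unreadable from compound 1 to compound 3. For compound 3 the estimate is 205000 nM, with an expected range of 100000 nM to 300000 nM.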

Compound 3, half-maximal cytotoxic concentration: > 205000 nM
Compound 3 was reported as a limit (the forecaster's own chance of this, stated with the estimate: 75%); the middle value lies on the limit itself.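

Among these compounds, compound 1 and compound 3 both stand only as limits in this assay, and no step between them can be read. The compounds shown leave open where the half-maximal cytotoxic concentration of any of them lies.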